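Flavanone series: removing the phenol on the fused ring

The source may hold more compounds than are shown below. What is called first, only, known or untested is meant among the compounds shown, and "the series" means these compounds.

Among the measured compounds shown here, compound 3 `COc1ccc(C2CC(=O)c3ccc(O)cc3O2)cc1CC=C(C)C` gives 4080 nM in an assay on isolated protein for inhibition of Aromatase (Homo sapiens) (a lower number here means a stronger inhibitor, a higher number a weaker inhibitor), the lowest of the two numbers measured so far. Its nearest neighbour is compound 2 `COCOc1ccc2c(c1)OC(c1ccc(OC)c(CC=C(C)C)c1)CC2=O`, which gives 7670 nM in this assay; the step of a 1.9-fold lower number from compound 2 to compound 3 (0.27 log units; within the scatter) stays within the scatter. Compound 1 `COCOc1ccc(C(=O)/C=C/c2ccc(OC)c(CC=C(C)C)c2)c(O)c1` returns only a limit in this assay, > 261000 nM (the limit of > 261000 nM in this assay, at which 1 of the 3 values shown sits), and no number.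

Compound 4 `COc1ccc(C2CC(=O)c3ccccc3O2)cc1CC=C(C)C` differs from compound 3 by hydrogen in place of hydroxy on an aromatic carbon of the fused ring. For the measured compounds named here, no measured step removes a hydroxy from this core. Going by the values given here, the only measured step touching an oxygen on the fused ring, a 1.9-fold lower number from compound 2 to compound 3 (0.27 log units; within the scatter), exchanged methoxymethyl for hydrogen and did not move the number beyond the scatter, so it bears on the present change only loosely. Among the compounds with values here, with no direct precedent, the working expectation for this assay is a small step, in either direction or none beyond the scatter, with a wide range to reflect the uncertainty. Compound 4 is therefore expected to give about 6000 nM in this assay, within 1500 nM to 25000 nM. The step of a 1.5-fold higher number from compound 3 to compound 4 (0.17 log units; within the scatter) that this estimate implies is expected to stay within the scatter.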

Compound 4, half-maximal inhibitory concentration: 12100 nM
The estimate for compound 4 lay 2.0-fold (0.30 log units) below the measured number; low and high end bracket the measured number.
By their numbers in this assay, from the lowest: compounds 3, 2 and 4 (each within the scatter of the next, the first and the last beyond it). At a limit, above all of these: compound 1.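

Hydrogen in place of hydroxy on this aromatic carbon gives the only step on the shared core that lies beyond the scatter, and a modest one: a 3.0-fold higher number from compound 3 to compound 4 (0.47 log units; beyond the scatter). Hydrogen in place of methoxymethoxy on the same carbon stays within the scatter, a 1.6-fold higher number from compound 2 to compound 4 (0.20 log units; within the scatter), so in this assay hydroxy at this position can be told apart from hydrogen, whereas methoxymethoxy cannot. Nothing at hand explains why the hydroxy makes this difference.

On these data alone, the three compounds give only three substituents at this position, and the gap between hydroxy and methoxymethoxy lies within the scatter, so it remains open whether a free hydrogen-bond donor is what matters here or only the particular hydroxy group. An amine or a carboxylic acid on this aromatic carbon would test this, and the compounds shown also leave open whether the hydroxy would count for as much on another carbon of the same ring.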